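Sulfonamide versus amide on the linker chain: working notes

A few compounds are considered here, and "the series" means these few. Any claim that something is new, unique, unknown or untested is made for them only; others in the source may bear on it.

Measured compounds in a functional assay on SK-MEL-28 cells (Homo sapiens) for cytotoxicity, read by MTT assay; a lower number here means a stronger inhibitor, a higher number a weaker inhibitor:
- compound 1, `O=S(=O)(NCCCNc1nccc(-c2c(-c3cccc(F)c3)nc3sccn23)n1)c1ccc(Br)cc1`: compound 1 gives 9400 nM
- compound 2, `O=C(NCCCNc1nccc(-c2c(-c3cccc(F)c3)nc3sccn23)n1)c1ccc(Cl)cc1`: compound 2 reaches only the assay limit, > 20000 nM

Compound 2 stands at the weak end of the two numbers shown; its value is a limit of this assay and not a number, so its true position is open. Compound 3, `O=S(=O)(NCCNc1nccc(-c2c(-c3cccc(F)c3)nc3sccn23)n1)c1ccccc1`, is not yet measured. Relative to compound 2 the change is (phenylsulfonyl)amino in place of (((4-chlorophenyl)carbonyl)amino)methyl on a saturated chain carbon, two bonds along the chain from a nitrogen on an aromatic ring. So the amide of compound 2 is exchanged for a sulfonamide, the chlorine on the ring is dropped, and the chain becomes one carbon shorter.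

Among the measured compounds shown here, the one measured step that bears on this is an at least 2.1-fold higher number from compound 1 to compound 2 (0.32 log units; beyond the scatter), in which an amide replaced a sulfonamide on the same nitrogen and the number rose to the limit (the limit of > 20000 nM in this assay, at which 1 of the 2 values shown sits). For the measured compounds named here, the present change runs in the opposite sense, so a return toward the region of compound 1 is expected, though the missing halogen and the shorter chain have no measured precedent here.

Compound 3 is therefore estimated at 10000 nM in this assay, with a likely range of 3000 nM to 30000 nM. This estimate means a step of an at least 2.0-fold lower number from compound 2 to compound 3 (0.30 log units; that floor lies within the scatter).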

Compound 3, half-maximal inhibitory concentration: 19000 nM
Compound 3: the middle estimate sits 1.9-fold (0.28 log units) below what was measured; measured number inside the range.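

In this assay, keeping a sulfonamide on the chain does not by itself hold the level of compound 1 once the bromine and one chain carbon are gone: the change to (phenylsulfonyl)amino gives a 2.0-fold higher number from compound 1 to compound 3 (0.31 log units; beyond the scatter). Exchanging the (((4-chlorophenyl)carbonyl)amino)methyl group of the amide for the same (phenylsulfonyl)amino group gives an at least 1.0-fold lower number from compound 2 to compound 3 (0.02 log units; that floor lies within the scatter), so no clear separation between these two groups is established at this place on the chain, and the sulfonamide in compound 3 sits close to the weak end of the series. Compound 2 remains a limit of the assay and not a number, which leaves the true size of that step open: the limit of > 20000 nM in this assay, at which 1 of the 3 values shown sits.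

Whether the loss from compound 1 follows the bromine or the shorter chain stays open, as the two change together in every comparison shown. Also open, as far as these compounds go, is how this assay would read for a longer chain, or for an amine or a carboxylic acid on the phenyl ring of the sulfonamide.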